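This account rests on a few compounds, and the source may have more. Where it says the series, first, only, none or still open, it means among the compounds named here.

Measured compounds:
- Compound 1, with the structure `CCCC(C)n1c(CC)nc2c(-c3ccc(Cl)cc3Cl)nccc21`, gives 3 nM in an assay for binding affinity to Corticotropin releasing factor receptor (Rattus norvegicus); on this read-out lower numbers stand for stronger inhibition and higher numbers for weaker inhibition.
- Compound 2, with the structure `CCc1nc2c(-c3ccc(C(F)(F)F)cc3Cl)nccc2n1C(CC)CC`, gives 5.4 nM in this assay.

Compound 2 stands at the higher of the two numbers, and its nearest neighbour is compound 1, whose number is lower by a margin that lies within the usual scatter of this assay; the two values therefore cannot be told apart. Among the measured compounds shown here, no step between measured compounds that differ in a single place is available here.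

Compound 3, with the structure `CCCC(C)n1c(CC)nc2c(-c3ccc(C(F)(F)F)cc3Cl)nccc21`, is not yet measured. It differs from compound 2 by the change (1-methylbutyl in place of pentan-3-yl on an aromatic nitrogen). Given that compound 1 and compound 2 sit together within the scatter, the step from compound 2 to compound 3 is expected to be small, in no particular direction, and most likely not beyond the scatter, namely a 1.4-fold lower number from compound 2 to compound 3 (0.13 log units; within the scatter). Compound 3 is therefore estimated at 4 nM in this assay, with a range from 1.5 nM to 12 nM.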

Compound 3, inhibition constant: 3.5 nM
Compound 3: middle estimate off by 1.1-fold (0.06 log units), on the high side; the measured number falls inside the stated range.
By their numbers in this assay, from the lowest: compounds 1, 3 and 2 (each within the scatter of the next).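

Among the compounds shown here, compound 3 supplies the first single-place comparisons in this set. On the aromatic nitrogen, 1-methylbutyl in place of pentan-3-yl, two chains of the same heavy-atom count joined differently, gives a 1.5-fold lower number from compound 2 to compound 3 (0.19 log units; within the scatter) in this assay, so these two branched chains cannot be told apart on this read-out. On the aromatic carbon, trifluoromethyl in place of chloro gives a 1.2-fold higher number from compound 1 to compound 3 (0.07 log units; within the scatter), so these two groups cannot be told apart either, and no measurement offered here speaks to what lies behind either step.

The compounds shown leave open whether a different group on that nitrogen, such as a cyclopropylmethyl group or a longer chain such as n-heptyl, would hold the number in this assay. They also leave open whether a methoxy group or a nitrile in place of trifluoromethyl on the aromatic carbon would do so.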